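From Chloro to Phenoxy: Estimating Compound 3

The source may hold more compounds than are shown below. What is called first, only, known or untested is meant among the compounds shown, and "the series" means these compounds.

Compound 1 `C[C@H](NC(=O)C(=O)NC1CCCCC1)C(=O)N[C@@H](CC(=O)O)C(=O)COc1c(F)c(F)cc(F)c1F` and compound 2 `C[C@H](NC(=O)C(=O)Nc1ccccc1Cl)C(=O)N[C@@H](CC(=O)O)C(=O)COc1c(F)c(F)cc(F)c1F` share one core and differ only at the amide-type nitrogen. In a functional assay on THP-1 cells (Homo sapiens) for inhibition (a higher number here means a weaker inhibitor, a lower number a stronger inhibitor), compound 1 gives 500 nM, and compound 2 gives 540 nM, the higher of the two numbers, though a 1.1-fold higher number from compound 1 to compound 2 (0.03 log units; within the scatter). Compound 3 `C[C@H](NC(=O)C(=O)Nc1ccccc1Oc1ccccc1)C(=O)N[C@@H](CC(=O)O)C(=O)COc1c(F)c(F)cc(F)c1F` keeps the core of compound 2 and carries phenoxy in place of chloro on an aromatic carbon. For the measured compounds named here, no measured step swaps these two groups; the only step known, a 1.1-fold higher number from compound 1 to compound 2 (0.03 log units; within the scatter), shows that the group on the amide-type nitrogen can change with little effect in this assay. A step of about a 1.1-fold higher number from compound 2 to compound 3 (0.05 log units; within the scatter) is therefore expected. Compound 3 is estimated at 600 nM, between 200 nM and 1800 nM.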

Compound 3, half-maximal inhibitory concentration: 800 nM
The estimate for compound 3 lay 1.3-fold (0.12 log units) below the measured number; the range from low to high includes it.
By their numbers in this assay, from the lowest: compounds 1, 2 and 3 (each within the scatter of the next).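

In this assay, replacing chloro with phenoxy gives a 1.5-fold higher number from compound 2 to compound 3 (0.17 log units; within the scatter). For the compounds shown here, this aromatic carbon, ortho to a large group, therefore accepts 7 heavy atoms and a six-membered aromatic ring in place of a single chlorine with no change beyond the scatter, whereas the earlier pair showed only that the whole group on the amide-type nitrogen could be exchanged. Nothing available explains this result. The compounds shown leave open whether an amine or a carboxylic acid on this aromatic carbon would also stay within the scatter.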